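The source may hold more compounds than are shown below. What is called first, only, known or untested is meant among the compounds shown, and "the series" means these compounds.

Three nucleoside analogues built on one shared core, differing only in the five-membered aromatic ring attached to it, have been measured in a functional assay on K562 cells (Homo sapiens), read by MTT assay, with a stated time of 72 h; on this read-out lower numbers stand for stronger inhibition and higher numbers for weaker inhibition. Compound 1 `O=c1[nH]cnc2c1c(-c1ccoc1)cn2[C@@H]1O[C@H](CO)[C@@H](O)[C@H]1O` gives 12500 nM in this assay. Compound 3 `O=c1[nH]cnc2c1c(-c1ccco1)cn2[C@@H]1O[C@H](CO)[C@@H](O)[C@H]1O` gives 15500 nM. Compound 2 `O=c1[nH]cnc2c1c(-c1ccsc1)cn2[C@@H]1O[C@H](CO)[C@@H](O)[C@H]1O` reaches only the limit of the assay, > 20000 nM, so no number is known for it.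

Among the two numbers, compound 3 is nominally the higher, but the step of a 1.2-fold higher number from compound 1 to compound 3 (0.09 log units; within the scatter) sits within the scatter, so compound 1 and compound 3 cannot be told apart. The remaining steps, an at least 1.6-fold higher number from compound 1 to compound 2 (0.20 log units; that floor lies within the scatter) and an at least 1.2-fold lower number from compound 2 to compound 3 (0.11 log units; that floor lies within the scatter), are floors only, since compound 2 stands at the limit of > 20000 nM in this assay, at which 1 of the 3 values shown sits, and both floors also fall within the scatter.

Compound 4 `Nc1nc2c(c(-c3ccco3)cn2[C@@H]2O[C@H](CO)[C@@H](O)[C@H]2O)c(=O)[nH]1` differs from compound 3 by amino in place of hydrogen on an aromatic carbon, at the aromatic carbon between two ring nitrogen atoms of the six-membered aromatic ring. Among the measured compounds shown here, none of the measured steps touches that part of the core; all three exchange only the five-membered ring. For the measured compounds named here, no measured step therefore bears on this change, and the expected step of a 1.3-fold lower number from compound 3 to compound 4 (0.11 log units; within the scatter) is none beyond the scatter. Compound 4 is expected to give about 12000 nM, within 3000 nM to 40000 nM.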

Compound 4, half-maximal inhibitory concentration: > 20000 nM
Compound 4: a limit, no number; the forecaster's own chance of this, stated with the estimate: 35%; at least 1.6-fold (0.22 log units) between middle value and limit.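

In this assay compound 4 gives > 20000 nM, which is a limit of the assay and not a number. Among the compounds shown here, this is the first look at the aromatic carbon between two ring nitrogen atoms, since all the earlier steps exchanged only the five-membered ring, and it shows that amino at this carbon, with furan-2-yl kept in place, brings no inhibition strong enough to be given as a number: the step is an at least 1.2-fold higher number from compound 3 to compound 4 (0.11 log units; that floor lies within the scatter), so it cannot be said whether amino weakens the inhibition or leaves it about unchanged, only that no gain appears. The size of any loss stays hidden, and the comparison among the compounds at this end of the range is cut short by a single limit: the limit of > 20000 nM in this assay, at which 2 of the 4 values shown sit.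

The compounds shown leave open whether a smaller or different group on this same carbon, such as a methyl group, a chlorine atom or a methylamino group, would give a readable number. They also leave open whether amino would behave the same way on a compound carrying furan-3-yl, the five-membered ring of compound 1, instead of furan-2-yl.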